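Cyclopropyl to 4-fluorophenyl on compound 2

A few compounds are considered here, and "the series" means these few. Any claim that something is new, unique, unknown or untested is made for them only; others in the source may bear on it.

In an ADME assay on Vero cells (Chlorocebus sabaeus) for cytotoxicity, read by MTT assay, with a stated time of 72 h (on this read-out lower numbers stand for stronger inhibition and higher numbers for weaker inhibition), compound 1 `CN1CCN(c2nc3c(cc2[N+](=O)[O-])c(=O)c(C(=O)O)cn3C2CC2)CC1c1ccccc1` gives 139000 nM and compound 2 `O=C(O)c1cn2c(n1)CN(c1nc3c(cc1[N+](=O)[O-])c(=O)c(C(=O)O)cn3C1CC1)CC2` gives 142000 nM, so these two values lie within the scatter of each other. Compound 4 `O=C(O)c1cn2c(n1)CN(c1nc3c(cc1[N+](=O)[O-])c(=O)c(C(=O)O)cn3-c1ccc(F)cc1)CC2` has 4-fluorophenyl in place of cyclopropyl on an aromatic nitrogen. Going by the values given here, no measured pair isolates this change, but no step beyond the scatter is expected in this assay, in either direction. That expectation rests on compound 3 `CCN(CC)C(=O)C1CCCN(c2nc3c(cc2[N+](=O)[O-])c(=O)c(C(=O)O)cn3-c2ccc(F)cc2)C1`, which also carries 4-fluorophenyl on an aromatic nitrogen and reads > 122000 nM, a limit of the assay and not a number. The expected step is a 1.1-fold lower number from compound 2 to compound 4 (0.04 log units; within the scatter). Compound 4 is estimated at 130000 nM, with an expected range of 65000 nM to 260000 nM.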

Compound 4, half-maximal inhibitory concentration: > 126000 nM
Compound 4 ended at the assay's limit; the forecaster's own chance of this, stated with the estimate: 35%; the middle value lies beyond the limit too.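

In this assay, going by these compounds alone, compound 4 reads > 126000 nM, which is a limit and not a number, so no step from compound 2 to it can be read. On these data alone, whether 4-fluorophenyl in place of cyclopropyl shifts the reading at all remains open.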